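The source may report more compounds than this note shows. Statements on the series, on what has been measured and on what is new or still open speak of the compounds shown alone.

Measured compounds in this series:

compound 1 `O=[N+]([O-])c1ccc(NC(=S)NCCNS(=O)(=O)c2ccc(-c3ccccc3O[C@H]3CC[C@@H](O)CC3)s2)cc1`; in an ADME assay on HEK-293T cells (Homo sapiens) for cytotoxicity, read by CCK-8 assay, with a stated time of 48 h (on this read-out higher numbers stand for weaker inhibition and lower numbers for stronger inhibition), compound 1 gives 20000 nM.
compound 2 `O=[N+]([O-])c1ccc(NC(=S)NCCNS(=O)(=O)c2ccc(-c3ccccc3OCc3ccccc3)s2)cc1`; in this assay compound 2 gives 8900 nM.
compound 3 `O=S(=O)(NCCNC(=S)Nc1cc(C(F)(F)F)cc(C(F)(F)F)c1)c1ccc(-c2ccccc2O[C@H]2CC[C@@H](O)CC2)s1`; compound 3 is reported only as a limit, > 20000 nM.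

One change, (benzyl in place of 4-hydroxycyclohexyl on an oxygen on an aromatic ring), is measured once: a 2.2-fold lower number from compound 1 to compound 2 (0.35 log units; beyond the scatter). The difference between the core of compound 1 and the core of compound 3 is not broken down here.

Compound 4 `O=S(=O)(NCCNC(=S)Nc1cc(C(F)(F)F)cc(C(F)(F)F)c1)c1ccc(-c2ccccc2OCc2ccccc2)s1` carries the same change on the core of compound 3, (benzyl in place of 4-hydroxycyclohexyl on an oxygen on an aromatic ring), at a place worded exactly as for compound 1 to compound 2. The step is expected to be of similar size, an at least 1.4-fold lower number from compound 3 to compound 4 (0.15 log units; that floor lies within the scatter), resting on a 2.2-fold lower number from compound 1 to compound 2 (0.35 log units; beyond the scatter). Since compound 3 sits at the limit of > 20000 nM in this assay, at which 1 of the 3 values shown sits, the starting point is uncertain and a limit remains possible for compound 4. Compound 4 is estimated at 14000 nM, between 5000 nM and 40000 nM.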

Compound 4, half-maximal inhibitory concentration: 8500 nM
For compound 4 the middle estimate is 1.6-fold (0.22 log units) above the measured one, within the range that was stated.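

In this assay, benzyl in place of 4-hydroxycyclohexyl on an oxygen on an aromatic ring gives a lower number on both cores, and on the second core the step is an at least 2.3-fold lower number from compound 3 to compound 4 (0.37 log units; beyond the scatter). The value of compound 3, > 20000 nM, is a limit and not a number. The direction of the step therefore carries over between these two cores, but equal size is not shown: the same change on two cores in this assay, a 2.2-fold lower number (0.35 log units; beyond the scatter) from compound 1 to compound 2 and an at least 2.3-fold lower number (0.37 log units; beyond the scatter) from compound 3 to compound 4; the limit leaves it open whether they differ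

The compounds shown leave open whether the step holds for other groups on that oxygen, such as a methyl, a longer carbon chain or a cyclohexyl without the hydroxyl. They also leave open whether it holds on any core beyond these two.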